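Clearance outlook for the step to compound 4

The compounds below may be only part of what the source reports. "The series", "measured", "known", "first", "only" and "open" are said of these compounds alone.

In an ADME assay on microsomes from liver (Rattus norvegicus) for metabolic stability (a lower number here means slower removal, a higher number faster removal of the compound), compound 1 (`Cc1ccc(NC(=O)c2cc(Oc3ccc(S(C)(=O)=O)cc3)cc(OC(C)C)c2)nc1`) gives 97 mL/min/kg and sits level with compound 3 (`CC(C)Oc1cc(Oc2ccc(S(C)(=O)=O)cc2)cc(-c2nccc(=O)[nH]2)c1`) at 105 mL/min/kg while compound 2 (`CC(C)Oc1cc(Oc2ccc(S(C)(=O)=O)cc2)cc(-c2cccc(=O)[nH]2)c1`) stands apart at 349 mL/min/kg on the fast-removal side. Compound 4 (`CC(C)Oc1cc(Oc2ccc(S(C)(=O)=O)cc2)cc(-c2ncc(Cl)c(=O)[nH]2)c1`) differs from compound 1 by one exchange on an aromatic carbon, meta to an isopropoxy group (a group of 8 heavy atoms (4 carbon, 2 nitrogen, 1 oxygen, 1 chlorine; one six-membered aromatic ring with 2 hetero atoms) in place of a group of 10 heavy atoms (7 carbon, 2 nitrogen, 1 oxygen; one six-membered aromatic ring with 1 hetero atom), on an aromatic carbon). The closest measured step is a 1.1-fold higher number from compound 1 to compound 3 (0.03 log units; within the scatter) with a six-membered aromatic ring with 2 hetero atoms entering, as it does here. With 1 hetero atom in the entering ring the result is a 3.6-fold higher number from compound 1 to compound 2 (0.56 log units; beyond the scatter) and the step back toward 2 hetero atoms is a 3.3-fold lower number from compound 2 to compound 3 (0.52 log units; beyond the scatter) within these three compounds. Among the compounds with values here, no measured compound carries chlorine, so its contribution is unknown and the range stays wide. The expected move in this assay is a 1.1-fold lower number from compound 1 to compound 4 (0.03 log units; within the scatter) and thus no step beyond the scatter is expected. For compound 4 the estimate is 90 mL/min/kg (expected range 40 mL/min/kg to 200 mL/min/kg).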

Compound 4, clearance: < 25.4 mL/min/kg
Compound 4 gave a limit, no number; the forecaster's own chance of this, stated with the estimate: 3%; middle value at least 3.5-fold (0.54 log units) from the limit.
By their numbers in this assay, from the lowest: compounds 1 and 3 (each within the scatter of the next); then compound 2. At a limit, below all of these: compound 4.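

In this assay compound 4 gives a limit, not a number: the limit of < 25.4 mL/min/kg in this assay, at which 1 of the 4 values shown sits.

Chloro in place of hydrogen is the only difference in an at least 4.1-fold lower number from compound 3 to compound 4 (0.61 log units; beyond the scatter), and this is the one change shown that goes beyond the scatter to the low side of the level held by compound 1 and compound 3. Replacing the (5-methylpyridin-2-yl)carbamoyl group gave no step beyond the scatter when it led to compound 3, but with the chloro present it gives an at least 3.8-fold lower number from compound 1 to compound 4 (0.58 log units; beyond the scatter), and the comparison with the pyridone-type ring of compound 2 gives an at least 13-fold lower number from compound 2 to compound 4 (1.13 log units; beyond the scatter).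

Going by these compounds, how far compound 4 lies past its limit stays unknown, as does whether chloro would give a similar step on the ring of compound 2. On these data alone, whether fluoro, methyl or a nitrile in place of the chloro would do the same also remains open.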